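Pyrrolidinyl in place of benzisoxazolyl: cytotoxicity notes

The source may report more compounds than this note shows. Statements on the series, on what has been measured and on what is new or still open speak of the compounds shown alone.

Compound 1 `Nc1cc(-c2ccccc2)ccc1Cn1cncc1CNc1ccc(-c2cncs2)c(-c2ccccc2)c1` and compound 3 `COc1ccc(NCc2cncn2Cc2ccc(-c3ccccc3)cc2N)cc1-c1ccccc1` share a core with compound 2 `c1ccc(-c2ccc(Cn3cncc3CNc3ccc(-c4onc5ccccc45)c(-c4ccccc4)c3)cc2)cc1`. In a toxicity assay on NIH3T3 cells (Mus musculus) for cytotoxicity, read by resazurin assay (on this read-out higher numbers stand for an effect only at larger amounts of compound and lower numbers for an effect already at smaller amounts), compound 1 gives only a limit, > 1000 nM. In this assay compound 3 likewise gives only a limit, > 1000 nM. Compound 2 gives only a limit as well, > 10000 nM. Among the compounds with values here, the one step between measured compounds, a step that the two limits leave unreadable from compound 1 to compound 3, is therefore unreadable. Compound 2 stands at the limit of > 10000 nM in this assay, at which 1 of the 3 values shown sits, while the other two sit at the limit of > 1000 nM in this assay, at which 2 of the 3 values shown sit; no measured number is available in this assay.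

Compound 4 `c1ccc(-c2ccc(Cn3cncc3CNc3ccc(N4CCCC4)c(-c4ccccc4)c3)cc2)cc1` differs from compound 2 by a group of 5 heavy atoms (4 carbon, 1 nitrogen; one five-membered non-aromatic ring with 1 hetero atom) in place of a group of 9 heavy atoms (7 carbon, 1 nitrogen, 1 oxygen; one five-membered aromatic ring with 2 hetero atoms, one six-membered aromatic ring of carbon only), on an aromatic carbon. Within the data shown here, no measured step bears on this change, and the only step available is unreadable, so no direction can be drawn from the data. Given that every value so far is a limit, compound 4 is expected to remain weakly cytotoxic, with the step of a number no higher from compound 2 to compound 4 (the limit leaves the size open) estimated as none beyond the scatter. Compound 4 is estimated at 10000 nM, in the range 2500 nM to 40000 nM.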

Compound 4, half-maximal effective concentration: > 1000 nM
Compound 4 ended at the assay's limit (the forecaster's own chance of this, stated with the estimate: 70%); the middle value lies beyond the limit too.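

The step between compound 2 and compound 4 cannot be read: both values in this assay are limits, not numbers. The compounds shown leave open whether pyrrolidin-1-yl in this place shifts cytotoxicity at all, and at what concentration any compound here takes effect.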